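Swapping the Tail Group on a Piperidine Ester Series

The source may report more compounds than this note shows. Statements on the series, on what has been measured and on what is new or still open speak of the compounds shown alone.

Measured so far:
- compound 1 `[N-]=[N+]=NCCCN1CCCC(COC(=O)c2ccccc2-c2ccccc2)C1`: 4270 nM
- compound 2 `O=C(OCC1CCCN(CCCc2ccccc2)C1)c1ccccc1-c1ccccc1`: 13500 nM; 13500 nM (2 entries)
- compound 3 `O=C(OCC1CCCN(CCCn2cc(-c3ccccc3)nn2)C1)c1ccccc1-c1ccccc1`: 6460 nM

Within the data shown here, in an in vitro functional assay on HEK ts201 cells for antagonist activity at Neuronal acetylcholine receptor; alpha4/beta2 (Homo sapiens), read by fluorescence and calcium flux (on this read-out higher numbers stand for weaker inhibition and lower numbers for stronger inhibition), compound 3 gives 6460 nM, the highest of the single numbers here; its nearest neighbour is compound 1, and the step of a 1.5-fold higher number from compound 1 to compound 3 (0.18 log units; within the scatter) stays within the scatter. Compound 2 has two entries rather than one number.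

Compound 4 `COc1ccc(OCCCCCN2CCCC(COC(=O)c3ccccc3-c3ccccc3)C2)cc1` differs from compound 3 by 2-(4-methoxyphenoxy)ethyl in place of 4-phenyl-1H-1,2,3-triazol-1-yl on a saturated chain carbon, three bonds along the chain from an amine nitrogen in a ring. Among the measured compounds shown here, only the step from compound 1 to compound 3 bears on this position, and it was flat, so another tail change at the same place is expected to stay modest. Compound 4 is therefore estimated at 8000 nM, with a range from 3000 nM to 25000 nM, meaning an expected step of a 1.2-fold higher number from compound 3 to compound 4 (0.09 log units; within the scatter).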

Compound 4, half-maximal inhibitory concentration: 14500 nM
Compound 4: middle estimate off by 1.8-fold (0.26 log units), on the low side; the range from low to high includes it.
By their numbers in this assay, from the lowest: compounds 1 and 3 (each within the scatter of the next); then compound 4.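

In this assay this position is no longer flat: the new tail gives a 2.2-fold higher number from compound 3 to compound 4 (0.35 log units; beyond the scatter) and, set against azido, gives a 3.4-fold higher number from compound 1 to compound 4 (0.53 log units; beyond the scatter) with both steps modest but beyond the scatter. Since 2-(4-methoxyphenoxy)ethyl and 4-phenyl-1H-1,2,3-triazol-1-yl hold the same count of heavy atoms, that count alone does not settle the reading here. Nothing available explains this shift. Going by these compounds, whether a tail ending in an amine or a carboxylic acid would give stronger inhibition stays open. So does whether any tail here can give a lower number than azido.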